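The source may report more compounds than this note shows. Statements on the series, on what has been measured and on what is new or still open speak of the compounds shown alone.

Measured compounds:
Compound 1 `Cc1ccccc1-n1nncc1CN1C(=O)C2(C(C#N)=C(N)Oc3c2c2nc4ccccc4nc2c2ccccc32)c2ccccc21`: in an ADME assay on L02 cells (Homo sapiens) for antiproliferative activity, read by MTT assay, with a stated time of 48 h (on this read-out higher numbers stand for weaker inhibition and lower numbers for stronger inhibition), compound 1 gives > 50000 nM, which is a limit of the assay and not a number.
Compound 2 `N#CC1=C(N)Oc2c(N)cc3nc4ccccc4nc3c2C12C(=O)N(Cc1cnnn1-c1cccc(C(F)(F)F)c1)c1ccccc12`: in this assay compound 2 gives 38100 nM.

For the measured compounds named here, compound 2 therefore holds the only number recorded in this assay; the other result recorded is the limit of > 50000 nM in this assay, at which 1 of the 2 values shown sits, so compound 2 cannot be placed against any measured neighbour, and no step between measured compounds is available.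

Compound 3 `N#CC1=C(N)Oc2c(N)cc3nc4ccccc4nc3c2C12C(=O)N(Cc1cnnn1-c1c(Cl)cc(Cl)cc1Cl)c1ccccc12` is not yet measured. It differs from compound 2 by 2,4,6-trichlorophenyl in place of 3-(trifluoromethyl)phenyl on an aromatic nitrogen.

Going by the values given here, with no measured step to lean on, the expectation rests on the position of compound 2 alone, which sits close to the upper limit of this assay. The step from a 1.0-fold higher number from compound 2 to compound 3 (0.02 log units; within the scatter) is expected to be small, with no direction beyond the usual scatter. Compound 3 is estimated to give 40000 nM in this assay, with a range from 15000 nM to 70000 nM, and there is a real chance that the assay will return only a limit, as it did for compound 1.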

Compound 3, half-maximal inhibitory concentration: > 50000 nM
Compound 3: no number, only a limit; the forecaster's own chance of this, stated with the estimate: 40%; at least 1.2-fold (0.09 log units) between middle value and limit.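

In this assay, for the compounds shown here, the position on the aromatic nitrogen now has a readable step for the first time: exchanging 3-(trifluoromethyl)phenyl for 2,4,6-trichlorophenyl gives an at least 1.3-fold higher number from compound 2 to compound 3 (0.11 log units; that floor lies within the scatter). Going by these compounds alone, compound 3 gives > 50000 nM, which is a limit of the assay and not a number, so this step has a floor but no measured size, and it shows only that the change did not bring the value down from the level of compound 2. The result also means that most of the compounds shown now end at the limit of the assay: the limit of > 50000 nM in this assay, at which 2 of the 3 values shown sit.

The true size of the step remains open, as does whether it lies beyond the scatter, since the compounds shown give only one number in this assay. As far as these compounds go, it is also open how this position would respond to a plain phenyl, to a phenyl carrying a methoxy group, an amine or a carboxylic acid, or to a longer alkyl chain in place of the aromatic ring.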